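Working notes: the step from compound 3 to compound 4

This account rests on a few compounds, and the source may have more. Where it says the series, first, only, none or still open, it means among the compounds named here.

Three compounds of the series carry numbers in an assay on isolated protein for inhibition of sodium channel protein type 9 subunit alpha (Mus musculus), read by patch clamp; on this read-out lower numbers stand for stronger inhibition and higher numbers for weaker inhibition. Compound 1 `O=C(Nc1ccccc1)C1CCN(CC(O)COc2ccc(C(F)(F)F)cc2)CC1` gives 800 nM. Compound 2 `O=C(c1ccccc1)c1ccccc1OCC(O)CN1CCC(C(=O)Nc2ccccc2)CC1` gives 1000 nM in this assay. Compound 3 `O=C(c1ccccc1)c1cccc(OCC(O)CN2CCC(N3Cc4ccccc4C3=O)CC2)c1` gives 960 nM in this assay. Among the three numbers compound 3 stands second highest; its nearest neighbour is compound 2 and its furthest is compound 1, and both gaps lie within the scatter, so the three numbers do not separate the compounds from one another. Across them, two different amide portions and two different aryl substituents all land in the same band.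

The unmeasured compound 4 `O=C1c2ccccc2CN1C1CCN(CC(O)COc2cccc(C(F)(F)F)c2)CC1` differs from compound 3 in one place: trifluoromethyl in place of benzoyl on an aromatic carbon. Going by the values given here, no measured pair differs in one place, so there is no measured step against which to weigh this change. Given that compound 1, which also carries a trifluoromethyl on its aryl ring, gives 800 nM in this assay, within the scatter of compound 3, the step is expected to be a 1.1-fold lower number from compound 3 to compound 4 (0.03 log units; within the scatter), with no direction beyond the scatter. Compound 4 is therefore estimated at 900 nM in this assay, with a range from 400 nM to 2000 nM.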

Compound 4, half-maximal inhibitory concentration: 790 nM
Beside the measured number, compound 4's estimate is 1.1-fold (0.06 log units) above it, within the range that was stated.
By their numbers in this assay, from the lowest: compounds 4, 1, 3 and 2 (each within the scatter of the next).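

In this assay the series now has its first pair differing in one place, and it reads as a 1.2-fold lower number from compound 3 to compound 4 (0.08 log units; within the scatter), so the two compounds are not separated. The change is not a small one in what is counted: benzoyl, with 8 heavy atoms, a six-membered aromatic ring and a hydrogen-bond acceptor, leaves, and trifluoromethyl, with 4 heavy atoms, no ring and no hydrogen-bond acceptor, enters, yet on this aromatic carbon, meta to a large group, both groups give numbers within the scatter of each other. No measurement is at hand that bears on why these two groups read alike.

This single step cannot tell whether any group on this aromatic carbon would move the number beyond the scatter, and the four numbers stand each within the scatter of the next, so no handle on the read-out has yet appeared. An amine, a carboxylic acid or a longer chain on the same carbon would show whether this insensitivity extends past benzoyl and trifluoromethyl.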